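This account rests on a few compounds, and the source may have more. Where it says the series, first, only, none or still open, it means among the compounds named here.

Compound 3 `OC[C@H]1O[C@@H](n2cnc3c(CN4CCCCC4)ncnc32)[C@H](O)[C@@H]1O` carries the shared core with a piperidin-1-yl group on a saturated chain carbon bound to an aromatic carbon. Within the data shown here, in a functional assay on Huh-7 cells (Homo sapiens) for cytotoxicity, read by MTT assay, with a stated time of 3 days (on this read-out higher numbers stand for lower toxicity in this test and lower numbers for higher toxicity in this test), compound 3 gives 87000 nM, the only value among the three that is a number rather than a limit. Compound 1 `O=c1ccccn1Cc1ncnc2c1ncn2[C@@H]1O[C@H](CO)[C@@H](O)[C@H]1O` in this assay reaches only the limit > 100000 nM. Compound 2 `OC[C@H]1O[C@@H](n2cnc3c(Cn4ccc5ccccc54)ncnc32)[C@H](O)[C@@H]1O` in this assay likewise stops at the limit > 250000 nM. The two measured steps toward compound 3 are thus read against limits: an at least 2.8-fold lower number from compound 2 to compound 3 (0.45 log units; beyond the scatter), and an at least 1.1-fold lower number from compound 1 to compound 3 (0.06 log units; that floor lies within the scatter). Compound 4 `OC[C@H]1O[C@@H](n2cnc3c(Cn4cccn4)ncnc32)[C@H](O)[C@@H]1O` differs from compound 3 by 1H-pyrazol-1-yl in place of piperidin-1-yl on a saturated chain carbon bound to an aromatic carbon. Both steps that bear on this change replaced the group of compound 1 or the 1H-indol-1-yl group of compound 2 with the piperidin-1-yl group and gave a lower number, the step from compound 2 clearly so; the move away from piperidin-1-yl is therefore expected to run the other way, and the estimated step is a 1.7-fold higher number from compound 3 to compound 4 (0.24 log units; within the scatter). Compound 4 is expected to give about 150000 nM in this assay, within a range from 60000 nM to 400000 nM, with a fair chance that only a limit is reported.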

Compound 4, half-maximal cytotoxic concentration: > 250000 nM
Compound 4: no number, only a limit; the forecaster's own chance of this, stated with the estimate: 60%; middle value at least 1.6-fold (0.22 log units) from the limit.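

In this assay, replacing piperidin-1-yl with 1H-pyrazol-1-yl on the saturated chain carbon bound to an aromatic carbon gives an at least 2.8-fold higher number from compound 3 to compound 4 (0.45 log units; beyond the scatter), the first measured step away from piperidin-1-yl. A five-membered aromatic ring thus joins the 1H-indol-1-yl group of compound 2 in standing clear of compound 3, though compound 1, also with an aromatic ring at this place, does not separate as clearly: an at least 1.1-fold lower number from compound 1 to compound 3 (0.06 log units; that floor lies within the scatter). The full size of the step from compound 3 stays hidden, since compound 4 is reported only as a limit: the limit of > 250000 nM in this assay, at which 2 of the 4 values shown sit.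

The steps from compound 1 and from compound 2 to compound 4 cannot be read, so these three aromatic groups cannot be ranked. The compounds shown leave open whether morpholin-4-yl or an open-chain diethylamino group at this place would behave like piperidin-1-yl.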